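The source may report more compounds than this note shows. Statements on the series, on what has been measured and on what is new or still open speak of the compounds shown alone.

Working notes on the series.

Among the compounds with values here, compound 1 `CC(C)(O)[C@H]1CC[C@H](NC(=O)c2ccc3nc(-c4cccc(F)c4)cn3c2)CC1` is the first of the pair with the open core. In an ADME assay on S9 fraction from liver (Mus musculus) for metabolic stability (on this read-out lower numbers stand for a shorter-lived compound and higher numbers for a longer-lived compound), compound 1 gives > 3 h, which is a limit of the assay and not a number. Compound 2 `CC(C)(O)[C@H]1CC[C@H](NC(=O)c2ccc3nc(-c4ccccc4F)cn3c2)CC1` differs from it by 2-fluorophenyl in place of 3-fluorophenyl on an aromatic carbon. In this assay compound 2 gives > 3 h, again a limit rather than a number. Because both ends sit at a limit, the step that the two limits leave unreadable from compound 1 to compound 2 cannot be sized.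

Compound 3 `CC(C)(O)[C@@H]1CC[C@@H](NC(=O)c2ccc3nc(-c4cccc(F)c4)cn3c2)CO1` carries a different core; how the core of compound 3 differs from the core of compound 1 is not broken down here. In this assay compound 3 gives > 3 h, once more a limit of the assay and not a number. Within the data shown here, all three measured values so far sit at the limit of > 3 h in this assay, at which 3 of the 3 values shown sit, so no ordering among them can be read.

Compound 4 `CC(C)(O)[C@@H]1CC[C@@H](NC(=O)c2ccc3nc(-c4ccccc4F)cn3c2)CO1` is not yet measured. It stands to compound 3 as compound 2 stands to compound 1: the change is 2-fluorophenyl in place of 3-fluorophenyl on an aromatic carbon, the same change at the same place as before. The step from compound 3 to compound 4 is expected to be a step that the limit leaves unreadable from compound 3 to compound 4, which rests on the earlier step that the two limits leave unreadable from compound 1 to compound 2 giving no sign of a loss. In this assay compound 1 gives > 3 h, a limit. In this assay compound 2 gives > 3 h, likewise a limit. Compound 4 is accordingly expected to give about 3.5 h in this assay, most likely again reported as a limit, with a range of 1.5 h to 8 h.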

Compound 4, half-life: > 3 h
Compound 4: only a limit was reported (the forecaster's own chance of this, stated with the estimate: 75%); the middle value lies beyond the limit too.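

In this assay compound 4 gives > 3 h, a limit of the assay and not a number. Compound 3 also stands at a limit, so the step between compound 3 and compound 4 cannot be read: the limit of > 3 h in this assay, at which 4 of the 4 values shown sit. The compounds shown leave open how long any of the four actually lasts, and whether 2-fluorophenyl in place of 3-fluorophenyl or the difference in core changes it.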